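This account rests on a few compounds, and the source may have more. Where it says the series, first, only, none or still open, it means among the compounds named here.

Working notes on the series. Four compounds are in view: compound 1 `COc1cccc(/C=C/C(=O)c2c(O)cc(OC)cc2OC)c1`, compound 2 `COc1cc(O)c(C(=O)/C=C/c2cccc(OC)c2OC)c(OC)c1`, compound 3 `COc1cc(OCC=C(C)C)c(C(=O)/C=C/c2cc(OC)c(OC)c(OC)c2)c(OC)c1CC=C(C)C` and compound 4 `COc1ccc(/C=C/C(=O)c2c(OCC=C(C)C)cc(OC)c(CC=C(C)C)c2OC)cc1OC`, the last of these not yet measured.

In a functional assay on HCT-116 cells (Homo sapiens) for antiproliferative activity, read by sulforhodamine B assay, with a stated time of 48 h (on this read-out higher numbers stand for weaker inhibition and lower numbers for stronger inhibition), compound 1 gives 3100 nM, compound 2 gives 3500 nM and compound 3 gives 4200 nM. All three numbers sit close together, and no order among them can be claimed.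

Compound 2 and compound 1 differ in one place, (hydrogen in place of methoxy on an aromatic carbon). The step of a 1.1-fold lower number from compound 2 to compound 1 (0.05 log units; within the scatter) is within the scatter.

The two cores of compound 3 and compound 2 differ in more than one place; the difference between them is not broken down here.

Compound 4 is obtained from compound 3 by the same kind of change, (hydrogen in place of methoxy on an aromatic carbon). The surroundings of the place are not identical: in compound 2 the methoxy that leaves stands ortho to a large group and ortho to a methoxy group, whereas in compound 3 it stands ortho to a methoxy group, meta to a large group and meta to a methoxy group. The change from compound 3 to compound 4 is therefore the same kind of change, not the same.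

For compound 4 in this assay a step of about a 1.1-fold lower number from compound 3 to compound 4 (0.02 log units; within the scatter) is expected, resting on the earlier step of a 1.1-fold lower number from compound 2 to compound 1 (0.05 log units; within the scatter), which stayed within the scatter. Compound 4 is accordingly estimated at 4000 nM, with a range from 2000 nM to 8000 nM.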

Compound 4, half-maximal inhibitory concentration: 7400 nM
For compound 4 the middle estimate is 1.9-fold (0.27 log units) below the measured one; measured number inside the range.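

In this assay the step of a 1.8-fold higher number from compound 3 to compound 4 (0.25 log units; within the scatter) joins the step of a 1.1-fold lower number from compound 2 to compound 1 (0.05 log units; within the scatter) as a second reading of hydrogen in place of methoxy on an aromatic carbon, so on both cores the change stays inside the usual scatter of the measurement. Among the compounds shown here, this does not show that the change is without effect, nor that it would behave alike on a further core: there are only two steps, the methoxy stands in different surroundings on the two cores, and steps of this size can neither confirm nor exclude a small difference between cores. As far as these two cores go, the change carries over without a difference that can be told from the noise: the same change on two cores in this assay, a 1.1-fold lower number (0.05 log units; within the scatter) from compound 2 to compound 1 and a 1.8-fold higher number (0.25 log units; within the scatter) from compound 3 to compound 4, 2.0-fold (0.30 log units) apart, within the scatter of two such steps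

The compounds shown leave open whether another group at this place, such as an amine or a carboxylic acid, or a longer chain in place of the methoxy, would move the number beyond the scatter. For the compounds shown here, also open is how the core of compound 2 and the core of compound 3 compare one difference at a time, as no step in a single place joins them.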